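Swapping furan for thiophene on a methylated chalcone-like compound

This account rests on a few compounds, and the source may have more. Where it says the series, first, only, none or still open, it means among the compounds named here.

Values in a functional assay on cells (Neutrophil, Rattus norvegicus) for inhibition; a higher number here means a weaker inhibitor, a lower number a stronger inhibitor:
- compound 1 `COc1ccc(OC)c(C(=O)/C=C/c2ccco2)c1`: 6200 nM
- compound 2 `COc1ccc(OC)c(C(=O)/C=C/c2cccs2)c1`: > 30000 nM (a limit of the assay, not a number)
- compound 3 `COc1ccc(OC)c(C(=O)/C=C/c2ccc(C)o2)c1`: 22200 nM

Of the two real numbers, compound 3 has the higher, at 22200 nM. The other is set by a 3.6-fold higher number from compound 1 to compound 3 (0.55 log units; beyond the scatter).

The next compound is compound 4 `COc1ccc(OC)c(C(=O)/C=C/c2ccc(C)s2)c1`, where 5-methylthiophen-2-yl takes the place of 5-methylfuran-2-yl: 5-methylthiophen-2-yl in place of 5-methylfuran-2-yl on a double-bonded chain carbon bound to a double-bonded chain carbon. Among the measured compounds shown here, the closest precedent is the same swap without the methyl, which gave an at least 4.8-fold higher number from compound 1 to compound 2 (0.68 log units; beyond the scatter). That step was beyond the scatter and is only a floor. The methyl step above shows that this group also changes the number, so the swap may not carry over in full size to a methylated compound. A rise is still expected in this assay, meaning a higher number and a weaker inhibitor, though probably a modest one.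

The expected change is a 2.3-fold higher number from compound 3 to compound 4 (0.35 log units; beyond the scatter). Compound 4 may well be reported only as a limit. For compound 4 the estimate is 50000 nM, with an expected range from 18000 nM to 130000 nM.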

Compound 4, half-maximal inhibitory concentration: > 30000 nM
Compound 4: only a limit was reported; the forecaster's own chance of this, stated with the estimate: 70%; the middle value is on the limit's open side.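

Read against compound 3, the swap to 5-methylthiophen-2-yl in this assay gives an at least 1.3-fold higher number from compound 3 to compound 4 (0.13 log units; that floor lies within the scatter), so a real rise is not established, and its true size cannot be seen because the reading stops at a limit of the assay: the limit of > 30000 nM in this assay, at which 2 of the 4 values shown sit. Measured from compound 1, which has neither the sulfur nor the methyl, the change is larger, with an at least 4.8-fold higher number from compound 1 to compound 4 (0.68 log units; beyond the scatter). Compound 4 is reported only as a limit, so adding the methyl to the thiophene gives a step that cannot be read, and the methyl effect seen with furan has no readable counterpart.

From the compounds shown here alone, how far compound 2 and compound 4 lie past the limit remains open. So does the effect of an amine or a carboxylic acid on the aromatic ring at this position.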